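One Stereocentre Changed, Growth Inhibition Still Unknown

The source may report more compounds than this note shows. Statements on the series, on what has been measured and on what is new or still open speak of the compounds shown alone.

Compound 1 `Cc1cn([C@H]2C[C@H](CC3=CC(=O)C(=O)C=C3)[C@@H](CO[Si](C)(C)C(C)(C)C)O2)c(=O)[nH]c1=O` has no result reported
Compound 2 `COc1ccc(C2([C@H]3C[C@H](n4cc(C)c(=O)[nH]c4=O)O[C@@H]3CO[Si](C)(C)C(C)(C)C)SCCCS2)cc1OC` gives 3310 nM

For the measured compounds named here, in a functional assay on MKN-45 cells (Homo sapiens) for inhibition, read by sulforhodamine B assay, with a stated time of 48 h (on this read-out higher numbers stand for weaker inhibition of growth and lower numbers for stronger inhibition of growth), compound 2 gives 3310 nM as the only number available. Going by the values given here, compound 1 has no result reported, so compound 2 cannot be ranked against any neighbour and there is no measured step to serve as a guide.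

The next compound to be tested is compound 3 `COc1ccc(C2([C@H]3C[C@@H](n4cc(C)c(=O)[nH]c4=O)O[C@@H]3CO[Si](C)(C)C(C)(C)C)SCCCS2)cc1OC` and the comparison with compound 2 is unusually narrow. The structural change is the two compounds have the same atoms and bonds and differ only in configuration as drawn: 1 of 3 stereo elements differ; a stereocentre at a saturated ring carbon is drawn R in compound 2 and S in compound 3 and a stereocentre at a saturated ring carbon is drawn R in compound 2 and S in compound 3. The two compounds have the same atoms and bonds.

Among the compounds with values here, the data contain no pair that shows what such a change does in this assay and so no direction can be favoured. The expected result is no step beyond the scatter, and the estimated step of a 1.1-fold higher number from compound 2 to compound 3 (0.02 log units; within the scatter) reflects that. Compound 3 is estimated at 3500 nM with an expected range from 1400 nM to 9000 nM on this read-out.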

Compound 3, concentration for 50% growth inhibition: 8320 nM
Compound 3: middle estimate off by 2.4-fold (0.38 log units), on the low side; the range from low to high includes it.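

In this assay, a change at a single stereocentre on a saturated ring carbon, drawn R in compound 2 and S in compound 3, gives a 2.5-fold higher number from compound 2 to compound 3 (0.40 log units; beyond the scatter). For the compounds shown here, this is the first measured step, and it shows that configuration at this position registers on this read-out, with the S drawing inhibiting growth more weakly than the R drawing. The step can be tied to that stereocentre alone because no other feature separates the pair: the fact that compounds 2 and 3 differ only in the configuration as drawn

The compounds shown rest on this single pair, so they leave open whether the same preference for the R drawing would hold once another part of the molecule changes, for instance with a free hydroxyl group in place of the silyl ether. They also do not tell why the configuration matters here, or whether a difference of this size would persist with an amine on the aromatic ring in place of a methoxy group.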